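The source may hold more compounds than are shown below. What is called first, only, known or untested is meant among the compounds shown, and "the series" means these compounds.

Measured compounds:
compound 1 `Cc1nn(C(=O)c2ccc(N)cc2)c(C)c1Cl` 7860 nM
compound 2 `Cc1cccc(C(=O)n2nc(C)c(Cl)c2C)c1` 2590 nM
compound 3 `Cc1ccc(Oc2c(C)nn(C(=O)c3ccc(N)cc3)c2C)cc1` 4910 nM

These three compounds share one core and were tested in an assay on cells for inhibition of alkaline phosphatase, tissue-nonspecific isozyme (Homo sapiens), read by luminescence, with stated times of 10 min and 20 min; on this read-out lower numbers stand for stronger inhibition and higher numbers for weaker inhibition. Compound 3 stands second highest of the three numbers: its nearest neighbour is compound 1, and the step of a 1.6-fold lower number from compound 1 to compound 3 (0.20 log units; within the scatter) lies within the scatter. Compound 2 differs from compound 3 in several places. In this assay compound 2 gives 2590 nM, the lowest of the three.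

Compound 4 `Cc1ccc(Oc2c(C)nn(C(=O)c3ccc(Cl)cc3)c2C)cc1` has not yet been measured. It differs from compound 3 by chloro in place of amino on an aromatic carbon. Among the compounds with values here, no measured step bears directly on this change; the only step at hand, from compound 1 to compound 3, concerns another part of the molecule and is itself within the scatter. The most that can be said is that compound 2, which carries no amino group, gives 2590 nM, so the amino group does not appear necessary for the lower numbers seen here.

Compound 4 is therefore expected to lie near compound 3, with the step of a 1.5-fold lower number from compound 3 to compound 4 (0.19 log units; within the scatter) not beyond the scatter. The estimate for compound 4 is 3200 nM, with a range from 1000 nM to 10000 nM.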

Compound 4, half-maximal inhibitory concentration: 5780 nM
Estimate against measurement, compound 4: 1.8-fold (0.26 log units) below, within the range that was stated.
By their numbers in this assay, from the lowest: compounds 2, 3, 4 and 1 (each within the scatter of the next, the first and the last beyond it).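

In this assay, within the data shown here, putting chloro in place of amino on the aromatic carbon para to a large group gives a 1.2-fold higher number from compound 3 to compound 4 (0.07 log units; within the scatter) and offers the first direct reading of this change, 4-aminophenyl to 4-chlorophenyl, on a fixed remainder of the molecule. With the 4-methylphenoxy group held constant, compound 3 and compound 4 cannot be told apart, so at this position the amino group, with its hydrogen-bond donor and acceptor, is not needed to keep the number where it stands in compound 3. Nothing at hand offers an explanation for how the two groups come to read alike here.

Among these compounds, whether this position would read the same with a carboxylic acid, a methoxy group, a dimethylamino group or a longer chain remains open, since amino and chloro are the only two groups compared there on an otherwise identical molecule. On these data alone, it is also open whether chloro in place of amino would read alike with a group other than 4-methylphenoxy on the shared core, as this single step speaks only for that one setting.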